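A few compounds are considered here, and "the series" means these few. Any claim that something is new, unique, unknown or untested is made for them only; others in the source may bear on it.

Measured compounds in a functional assay on NCI-H661 cells (Homo sapiens) for cytotoxicity, read by WST assay, with a stated time of 72 h; on this read-out higher numbers stand for weaker inhibition and lower numbers for stronger inhibition:
Compound 1 `COc1cc2c(Nc3nc4ccc(C(=O)Nc5c(C)cccc5C)cc4s3)ncnc2cc1OCCCN1CCCCC1` — in this assay compound 1 gives > 100000 nM, which is a limit of the assay and not a number.
Compound 2 `COc1cc2c(Nc3nc4ccc(C(=O)Nc5c(C)cccc5C)cc4s3)ncnc2cc1OCCCN1CCCCC1C` — in this assay compound 2 gives 84400 nM.
Compound 3 `COc1cc2c(Nc3nc4ccc(C(=O)Nc5c(C)cccc5Cl)cc4s3)ncnc2cc1OCCCN1CCCCC1` — in this assay compound 3 gives 13800 nM.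

Of the two numbers, compound 3 has the lower and compound 2 the higher. The cores of compound 1 and compound 3 differ by chloro in place of methyl on an aromatic carbon; this gives an at least 7.2-fold lower number from compound 1 to compound 3 (0.86 log units; beyond the scatter), and since the value of compound 1 is a limit, only a floor for the step is known.

Compound 1 and compound 2 differ by methyl in place of hydrogen on a saturated ring carbon. The step is an at least 1.1-fold lower number from compound 1 to compound 2 (0.07 log units; that floor lies within the scatter); here too only a floor is known.

Compound 4 `COc1cc2c(Nc3nc4ccc(C(=O)Nc5c(C)cccc5Cl)cc4s3)ncnc2cc1OCCCN1CCC(C)CC1` has not yet been measured. It differs from compound 3 by methyl in place of hydrogen on a saturated ring carbon. This is the same kind of change as that from compound 1 to compound 2, but not the same: there the methyl sat next to the ring nitrogen and next to the ring atom that bears a large group, whereas in compound 4 it sits three ring bonds from the ring nitrogen and three ring bonds from the ring atom that bears a large group. Going by these compounds, since the step from compound 1 to compound 2 rests on a limit, its true size is unknown, and its floor lies within the scatter. Compound 4 is therefore expected to show a step of a 1.3-fold lower number from compound 3 to compound 4 (0.10 log units; within the scatter) in this assay, a small move from compound 3. Compound 4 is estimated at 11000 nM, expected to lie between 3500 nM and 40000 nM.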

Compound 4, half-maximal inhibitory concentration: 7900 nM
For compound 4 the middle estimate is 1.4-fold (0.14 log units) above the measured one; low and high end bracket the measured number.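

In this assay, among these compounds, going from piperidin-1-yl to 4-methylpiperidin-1-yl on the core of compound 3 gives a 1.7-fold lower number from compound 3 to compound 4 (0.24 log units; within the scatter), so on this core the added methyl, three ring bonds from the ring nitrogen, produces no step that stands clear of the scatter. Whether the same kind of change carries over unchanged between the two cores cannot be settled, and the earlier step offers only a floor for comparison: the same change on two cores in this assay, an at least 1.1-fold lower number (0.07 log units; that floor lies within the scatter) from compound 1 to compound 2 and a 1.7-fold lower number (0.24 log units; within the scatter) from compound 3 to compound 4; the limit leaves it open whether they differ. Compound 1 gives > 100000 nM, which is a limit of the assay and not a number, so the pair shows neither that the change transfers nor that it does not, and the methyl also occupies a different ring place in compound 2 than in compound 4.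

The compounds shown leave open whether 4-methylpiperidin-1-yl on the core of compound 1 would give a measurable number rather than a limit, which would allow a comparison of the same change at the same ring place on both cores. They also leave open how a hydroxyl or an ethyl on that same ring carbon, or a morpholine in place of the piperidine, would read in this assay.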